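The source may report more compounds than this note shows. Statements on the series, on what has been measured and on what is new or still open speak of the compounds shown alone.

Measured so far in a functional assay on SK-MEL-2 cells (Homo sapiens) for inhibition, read by sulforhodamine B assay, with a stated time of 48 h, tested at 0.01 uM; a higher number here means a weaker effect of the compound at the concentration tested, a lower number a stronger effect:
- compound 1 `O=C(Nc1cccc(-n2cc(-c3ccncc3)c(-c3cc(O)cc(Cl)c3)n2)c1)Nc1ccc(Cl)c(C(F)(F)F)c1` gives 99%
- compound 2 `COc1cc(Cl)cc(-c2nn(-c3cccc(NC(=O)Nc4ccc(Cl)c(C(F)(F)F)c4)c3)cc2-c2ccncc2)c1` gives 102%
- compound 3 `COc1cc(Cl)cc(-c2nn(-c3cccc(NC(=O)Nc4cc(C(F)(F)F)cc(C(F)(F)F)c4)c3)cc2-c2ccncc2)c1` gives 103%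

Compound 3 holds the highest of the three numbers, yet its gaps to compound 2 and to compound 1 are both within the scatter, so the three sit together near the unchanged level. For the measured compounds named here, the single step measured in one place, a number 3 percentage points higher from compound 1 to compound 2 (within the scatter), also stayed within the scatter.

Compound 4 `COc1cc(Cl)cc(-c2nn(-c3cccc(NC(=O)Nc4cccc(C(F)(F)F)c4)c3)cc2-c2ccncc2)c1` differs from compound 3 by hydrogen in place of trifluoromethyl on an aromatic carbon. Going by the values given here, no measured step removes a trifluoromethyl, so the one step on record bears only indirectly; with every measured compound near the unchanged level in this assay, the expected step of a number 3 percentage points lower from compound 3 to compound 4 (within the scatter) is none beyond the scatter. Compound 4 is therefore estimated at 100%, with a range of 90% to 110%.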

Compound 4, a percentage reported as activity, at one concentration (the size of the read-out at that concentration, not a potency): 95%
Beside the measured number, compound 4's estimate is 5 percentage points above it, within the range that was stated.
By their numbers in this assay, from the lowest: compounds 4, 1, 2 and 3 (each within the scatter of the next).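

In this assay, the ring carrying the trifluoromethyl groups gives up a substituent with no readable change: a number 8 percentage points lower from compound 3 to compound 4 (within the scatter) on losing a trifluoromethyl and a number 7 percentage points lower from compound 2 to compound 4 (within the scatter) on losing the chloro. Compound 4 keeps a single trifluoromethyl on that ring and still sits with the other compounds near the unchanged level. Nothing at hand gives a reason for this result.

Going by these compounds, whether an amine or a carboxylic acid in place of the remaining trifluoromethyl would move the read-out stays open. So does whether any of these compounds has an effect at a higher concentration.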